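From propyl to 3-(diethylamino)propyl on a shared core

The source may report more compounds than this note shows. Statements on the series, on what has been measured and on what is new or still open speak of the compounds shown alone.

Values so far in a functional assay on Raji cells (Homo sapiens) for antiproliferative activity, read by MTT assay, with a stated time of 48 h; on this read-out higher numbers stand for weaker inhibition and lower numbers for stronger inhibition
Compound 1 (`CN(C)CCn1c(N)c(-c2nc3ccccc3[nH]2)c2nc(C#N)c(C#N)nc21`) gives 8320 nM
Compound 2 (`CCN(CC)CCn1c(N)c(-c2nc3ccccc3[nH]2)c2nc(C#N)c(C#N)nc21`) gives 8950 nM
Compound 3 (`CCCn1c(N)c(-c2nc3ccccc3[nH]2)c2nc(C#N)c(C#N)nc21`) gives > 50000 nM as a limit and not as a number

Compound 3 yields no number and stands at the limit of > 50000 nM in this assay, at which 1 of the 3 values shown sits, in this small set. The change from compound 3 to compound 4 (`CCN(CC)CCCn1c(N)c(-c2nc3ccccc3[nH]2)c2nc(C#N)c(C#N)nc21`) is diethylamino in place of hydrogen on a saturated chain carbon, three bonds along the chain from an aromatic nitrogen and turns propyl into 3-(diethylamino)propyl. Going by the values given here, two measured steps bear on it, and both must be read in reverse: an at least 6.0-fold higher number from compound 1 to compound 3 (0.77 log units; beyond the scatter) and an at least 5.5-fold higher number from compound 2 to compound 3 (0.74 log units; beyond the scatter) are each beyond the scatter, and each is bounded on one side only. Dimethylamino and diethylamino are not told apart, with a 1.1-fold higher number from compound 1 to compound 2 (0.03 log units; within the scatter) between them. Among the compounds with values here, in compound 4 the diethylamino stands three bonds along the chain from an aromatic nitrogen, whereas in compound 2 it stands two bonds along, and no measured step covers that difference. A step of similar size towards lower numbers is therefore expected in this assay, placing compound 4 in the region of compound 1 at 8320 nM and compound 2 at 8950 nM on this reading. The expected step is an at least 6.2-fold lower number from compound 3 to compound 4 (0.79 log units; beyond the scatter) by this estimate. Compound 4 is estimated at 8000 nM with an expected span from 2500 nM to 25000 nM as its range.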

Compound 4, half-maximal inhibitory concentration: 1870 nM
Compound 4: middle estimate off by 4.3-fold (0.63 log units), on the high side; the measured number lies below the stated range.
By their numbers in this assay, from the lowest: compound 4; then compounds 1 and 2 (each within the scatter of the next). At a limit, above all of these: compound 3.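

In this assay, diethylamino at the end of the propyl chain, three bonds along the chain from an aromatic nitrogen, brings a large change, an at least 26-fold lower number from compound 3 to compound 4 (1.42 log units; beyond the scatter), and this step is bounded on one side only. Its starting point, compound 3, is a limit and not a number: the limit of > 50000 nM in this assay, at which 1 of the 4 values shown sits. The earlier compounds shown here showed no difference between dimethylamino and diethylamino on the shorter chain, whereas the longer chain of compound 4 shows that the place of the amine along the chain does move the result, with a 4.8-fold lower number from compound 2 to compound 4 (0.68 log units; beyond the scatter) and a 4.4-fold lower number from compound 1 to compound 4 (0.65 log units; beyond the scatter), both beyond the scatter.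

The compounds shown leave open whether a still longer chain, such as a butyl chain ending in diethylamino, would continue towards lower numbers or turn back. They also leave open whether dimethylamino on the propyl chain would match compound 4, and whether a primary amine, a morpholine ring or a carboxylic acid at the chain end would keep any of this change.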